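This account rests on a few compounds, and the source may have more. Where it says the series, first, only, none or still open, it means among the compounds named here.

Measured so far:
compound 1 `CCC(=O)N(C)c1ccc2[nH]c(-c3n[nH]c4ccccc34)cc2n1` — 9300 nM
compound 2 `CN(C(=O)c1ccc([N+](=O)[O-])cc1)c1ccc2[nH]c(-c3n[nH]c4ccccc34)cc2n1` — 20200 nM

In a functional assay on KB cells (Homo sapiens) for antiproliferative activity, read by MTT assay, with a stated time of 72 h (on this read-out higher numbers stand for weaker inhibition and lower numbers for stronger inhibition), compound 1 gives 9300 nM. In the same assay compound 2 gives 20200 nM. Within the data shown here, compound 2 thus stands at the higher of the two numbers recorded, with compound 1 as its only neighbour; the single measured step is a 2.2-fold higher number from compound 1 to compound 2 (0.34 log units; beyond the scatter).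

Compound 3 `CN(C(=O)Nc1ccccc1)c1ccc2[nH]c(-c3n[nH]c4ccccc34)cc2n1` differs from compound 2 in one place: anilino in place of 4-nitrophenyl on a carbonyl carbon. Among the measured compounds shown here, no measured step covers an anilino group, so only the step from compound 1 to compound 2 bears on this, and it does so loosely: it shows that the 4-nitrophenyl group, now removed, was associated with a modest rise in the number on this assay. Removing it is therefore expected to give a modest step downward, estimated as a 1.7-fold lower number from compound 2 to compound 3 (0.23 log units; within the scatter), though a result within the scatter would not surprise. Compound 3 is expected to give about 12000 nM, with a range of 4000 nM to 36000 nM.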

Compound 3, half-maximal inhibitory concentration: 32 nM
Beside the measured number, compound 3's estimate is 380-fold (2.57 log units) above it; the whole stated range lies above it.
By their numbers in this assay, from the lowest: compound 3; then compound 1; then compound 2.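

In this assay anilino on the carbonyl carbon gives a 630-fold lower number from compound 2 to compound 3 (2.80 log units; beyond the scatter) and a 290-fold lower number from compound 1 to compound 3 (2.46 log units; beyond the scatter) and so shows this position to be far more sensitive than the earlier step of a 2.2-fold higher number from compound 1 to compound 2 (0.34 log units; beyond the scatter) suggested. Ethyl and 4-nitrophenyl both leave the numbers high, so the change of group here can matter far more than the difference between those two groups. Anilino carries a hydrogen-bond donor and 4-nitrophenyl carries none, but nothing available explains the size of these steps.

Open, as far as these compounds go, is whether the drop follows the hydrogen-bond donor or the phenyl ring, which a methylamino or a benzyl group on the same carbonyl carbon would help separate. Also open, from the compounds shown here alone, is how a methoxy group or a chlorine on the anilino ring would move the number.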